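A few compounds are considered here, and "the series" means these few. Any claim that something is new, unique, unknown or untested is made for them only; others in the source may bear on it.

The study gathers three compounds that share one core and a fourth that has not yet been tested. Compound 1 `COc1ccc(Cl)cc1NC(=O)CN(c1cc(Cl)ccc1OC)S(=O)(=O)c1ccccc1` was measured in a functional assay on SH-SY5Y cells (Homo sapiens), read by MTT assay, with a stated time of 24 h; a lower number here means that less compound is needed, a higher number that more compound is needed for the effect; the number for compound 1, > 20000 nM, is a limit of the assay and not a measured value. Compound 2 `COc1ccc(CNC(=O)CN(c2cc(Cl)ccc2OC)S(=O)(=O)c2ccccc2)cc1` likewise gives only a limit in this assay, > 20000 nM. Compound 3 `CCCNC(=O)CN(c1cc(Cl)ccc1OC)S(=O)(=O)c1ccccc1` also stops at a limit in this assay, > 20000 nM. Compound 2 thus stands at the limit, as do both other compounds; the common ground is the limit of > 20000 nM in this assay, at which 3 of the 3 values shown sit. With every value a limit, the steps between these compounds cannot be read: a step that the two limits leave unreadable from compound 1 to compound 2, a step that the two limits leave unreadable from compound 1 to compound 3 and a step that the two limits leave unreadable from compound 2 to compound 3 all remain without a size.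

Compound 4 `COc1ccc(Cl)cc1N(CC(=O)Nc1ccc([N+](=O)[O-])cc1)S(=O)(=O)c1ccccc1` differs from compound 2 in a single place: 4-nitrophenyl in place of 4-methoxybenzyl on an amide-type nitrogen. The steps that touch the same amide-type nitrogen, from compound 1 to compound 2 and from compound 2 to compound 3, bear most closely on this change, yet neither has a readable size, so no direction beyond the scatter can be expected in this assay. The expected step from compound 2 to compound 4 is estimated as a number no higher from compound 2 to compound 4 (the limit leaves the size open). For compound 4 the estimate in this assay is 20000 nM, within a range from 5000 nM to 80000 nM, most likely reported again only as a limit.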

Compound 4, half-maximal effective concentration: 8210 nM
Compound 4: middle estimate off by 2.4-fold (0.39 log units), on the high side; low and high end bracket the measured number.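

In this assay, the amide-type nitrogen now proves able to shift the number: the change to 4-nitrophenyl gives an at least 2.4-fold lower number from compound 2 to compound 4 (0.38 log units; beyond the scatter), and the same group gives an at least 2.4-fold lower number from compound 3 to compound 4 (0.38 log units; beyond the scatter) and an at least 2.4-fold lower number from compound 1 to compound 4 (0.38 log units; beyond the scatter). Each of these sizes is a lower bound, as the starting compound of every step stands at a limit, and a six-membered aromatic ring set directly on this nitrogen is not enough in itself, as compound 1 carries one in its 5-chloro-2-methoxyphenyl group and still stops at that limit. Compound 4 is the only one of the four to leave the common ground of the series: the limit of > 20000 nM in this assay, at which 3 of the 4 values shown sit.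

The steps among compounds 1, 2 and 3 still cannot be read, so nothing can be said about how the groups at the limit rank against one another. Compound 4 alone cannot separate the nitro group from the shorter link to the ring, and the compounds shown do not tell how a plain phenyl, a 4-aminophenyl or a 4-cyanophenyl group on the same nitrogen would compare.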